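Methyl in Place of Chloro and Tolerance in THP-1 Cells

A few compounds are considered here, and "the series" means these few. Any claim that something is new, unique, unknown or untested is made for them only; others in the source may bear on it.

Three compounds have been measured in a toxicity assay on THP-1 cells (Homo sapiens) for inhibition; a lower number here means that less compound is tolerated, a higher number that more compound is tolerated:

Compound 1 `Cc1ccc(-c2cnc(NC(=O)c3ccc(F)cc3)n2C)cc1` gives 60000 nM.
Compound 2 `Cn1c(-c2ccc(Cl)cc2)cnc1NC(=O)c1ccc(F)cc1` gives 37000 nM.
Compound 3 `Cn1c(-c2ccccc2)cnc1NC(=O)c1ccc(Cl)cc1` gives > 100000 nM, which is a limit of the assay and not a number.

The first two compounds share a core and differ in one place, (methyl in place of chloro on an aromatic carbon). That change gave a 1.6-fold higher number from compound 2 to compound 1 (0.21 log units; within the scatter), so the two values sit within the scatter of each other and no order between them can be read.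

The same change now stands to be made on a different core. Compound 4 `Cc1ccc(C(=O)Nc2ncc(-c3ccccc3)n2C)cc1` differs from compound 3 by methyl in place of chloro on an aromatic carbon. The difference between the core of compound 3 and the core of compound 2 is not broken down here. What is known of compound 3 is the limit of > 100000 nM in this assay, at which 1 of the 3 values shown sits, so only a lower bound for its value exists.

The earlier step gives the best guide to the new one. Because a 1.6-fold higher number from compound 2 to compound 1 (0.21 log units; within the scatter) was within the scatter, the step that the limit leaves unreadable from compound 3 to compound 4 is expected to be small as well. Since compound 3 itself sits at the limit, compound 4 is expected to give around 120000 nM, most likely again reported only as a limit, with a plausible range from 50000 nM to 300000 nM.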

Compound 4, half-maximal cytotoxic concentration: > 50000 nM
Compound 4: no number, only a limit; the forecaster's own chance of this, stated with the estimate: 70%; the middle value does not contradict the limit.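

In this assay compound 4 gives > 50000 nM, which is a limit of the assay and not a number. Compound 3 gives > 100000 nM, which is also a limit, so the step between these two compounds cannot be read. On these data alone, whether methyl in place of chloro shifts the number at all on the core of compound 3, and by how much, remains open.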